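From 4-methoxybenzyl to 3,4-difluorobenzyl: notes on the series

A few compounds are considered here, and "the series" means these few. Any claim that something is new, unique, unknown or untested is made for them only; others in the source may bear on it.

Measured in an ADME assay on the whole organism (strain Sprague-Dawley) for pharmacokinetics, with Rattus norvegicus as the target, using cassette dosing, at a dose of 1 mg/kg by the oral route; a lower number here means that a smaller share of the oral dose reaches the circulation, a higher number that a larger share of the oral dose reaches the circulation:
- compound 1 `O=C(C[C@]1(O)CC[C@H](Cc2ccccc2)CC1)Nc1ccc2[nH]c(=O)oc2c1` gives 33%
- compound 2 `O=C(C[C@]1(O)CC[C@H](Cc2ccc(F)cc2)CC1)Nc1ccc2[nH]c(=O)oc2c1` gives 58%
- compound 3 `COc1ccc(C[C@H]2CC[C@](O)(CC(=O)Nc3ccc4[nH]c(=O)oc4c3)CC2)cc1` gives 16%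

Compound 3 is the lowest of the three, and its gaps to compound 1 and compound 2 both lie beyond the scatter. The next compound is compound 4 `O=C(C[C@]1(O)CC[C@@H](Cc2ccc(F)c(F)c2)CC1)Nc1ccc2[nH]c(=O)oc2c1`, which differs from compound 3 as follows: 3,4-difluorophenyl in place of 4-methoxyphenyl on a saturated chain carbon bound to a saturated ring carbon. In short, 3,4-difluorophenyl stands in place of 4-methoxyphenyl on a saturated chain carbon bound to a saturated ring carbon.

Among the measured compounds shown here, one measured step bears on this change, fluoro in place of hydrogen on an aromatic carbon: a number 25 percentage points higher from compound 1 to compound 2 (beyond the scatter). It is modest in size. For the measured compounds named here, no measured step removes a 4-methoxyphenyl or adds a second fluoro, so the transfer is indirect. A rise in this assay larger than that step is expected because compound 2 stands at 58%. The estimated change is a number 32 percentage points higher from compound 3 to compound 4 (beyond the scatter). For compound 4 the expected value is 48%, with an estimated range of 25% to 70%.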

Compound 4, oral bioavailability: 12.1%
The estimate for compound 4 lay 35.9 percentage points above the measured number; measured number outside the range, below it.
By their numbers in this assay, from the lowest: compounds 4 and 3 (each within the scatter of the next); then compound 1; then compound 2.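

In this assay the change from 4-methoxyphenyl to 3,4-difluorophenyl on a saturated chain carbon bound to a saturated ring carbon reads a number 3.9 percentage points lower from compound 3 to compound 4 (within the scatter) and so does not separate these two groups at this position. Among the compounds shown here, the rise seen for a single fluoro, a number 25 percentage points higher from compound 1 to compound 2 (beyond the scatter), has no counterpart in this change, so a fluoro on this phenyl does not by itself go with a larger share of the oral dose reaching the circulation; compound 4 stands against any such rule. Nothing at hand bears on the reason for this result.

Still open, on these data alone, is how a chloro or a nitrile on the phenyl would read in this assay. As far as these compounds go, a pyridine ring in place of the phenyl, on the same saturated chain carbon, is equally open.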